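The source may report more compounds than this note shows. Statements on the series, on what has been measured and on what is new or still open speak of the compounds shown alone.

Compound 1 `Cc1ccc(OP(=O)(O)OC[C@H]2O[C@@H](n3cc(C)c(=O)[nH]c3=O)C[C@@H]2N=[N+]=[N-])cn1`: 28.9 h
Compound 2 `Cc1cn([C@H]2C[C@H](N=[N+]=[N-])[C@@H](COP(=O)(O)Oc3ccc(C#N)cc3)O2)c(=O)[nH]c1=O`: 7.08 h

In a physicochemical assay for metabolic stability, read by HPLC (a higher number here means that the compound lasts longer, a lower number that the compound disappears faster), compound 2 holds the lower of the two numbers, at 7.08 h. Compound 3 `Cc1cn([C@H]2C[C@H](N=[N+]=[N-])[C@@H](COP(=O)(O)Oc3ccc(Cl)cc3)O2)c(=O)[nH]c1=O` differs from it in one place, with chloro in place of cyano on an aromatic carbon, para to a large group (chloro in place of cyano on an aromatic carbon). Among the compounds with values here, the one measured step that bears on this is a 4.1-fold lower number from compound 1 to compound 2 (0.61 log units; beyond the scatter), where the 4-cyanophenyl group came in. Here the aromatic ring stays, and only its cyano group is exchanged, so a smaller step towards a higher number is expected: a 2.0-fold higher number from compound 2 to compound 3 (0.30 log units; within the scatter). The half-life of compound 3 is estimated at 14 h, with an expected range of 7.5 h to 27 h.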

Compound 3, half-life: 5.5 h
Estimate against measurement, compound 3: 2.5-fold (0.41 log units) above, and the stated range ends above it.
By their numbers in this assay, from the lowest: compounds 3 and 2 (each within the scatter of the next); then compound 1.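

In this assay, putting chloro in place of cyano on this aromatic carbon leaves the two compounds indistinguishable (a 1.3-fold lower number from compound 2 to compound 3 (0.11 log units; within the scatter)). The 4-chlorophenyl group, like the 4-cyanophenyl group, gives a lower half-life than the 6-methylpyridin-3-yl group (a 5.3-fold lower number from compound 1 to compound 3 (0.72 log units; beyond the scatter)). Nothing available here explains either step.

On these data alone, whether an amine or a carboxylic acid at this place would shift the half-life remains open. So does whether the gap to compound 1 follows the ring nitrogen or the methyl of its 6-methylpyridin-3-yl group.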